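The source may report more compounds than this note shows. Statements on the series, on what has been measured and on what is new or still open speak of the compounds shown alone.

Compound 1 `CC1CCC(C(=O)N2CC(c3nc(-c4cccc(Cl)c4)no3)C2)CC1` is the reference point of this account. In an assay on HEK293 cells for positive allosteric modulation of metabotropic glutamate receptor 5 (Homo sapiens), read by FLIPR (a higher number here means that more compound is needed for the effect, a lower number that less compound is needed), compound 1 gives 1500 nM, which is the highest of the two numbers measured here. For the measured compounds named here, compound 2 `O=C(C1CCC(C(F)(F)F)CC1)N1CC(c2nc(-c3cccc(Cl)c3)no2)C1` gives 1000 nM in this assay, and the step of a 1.5-fold lower number from compound 1 to compound 2 (0.18 log units; within the scatter) is the only measured step between two compounds that differ in a single place. Compound 3 `O=S(=O)(c1ccc(F)cc1)N1CC(c2nc(-c3cccc(Cl)c3)no2)C1` delivers no number in this assay but only a limit, > 10000 nM. That limit is one of the values in hand (the limit of > 10000 nM in this assay, at which 1 of the 3 values shown sits).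

Compound 4 `O=C(N1CCCCC1)N1CC(c2nc(-c3cccc(Cl)c3)no2)C1` differs from compound 1 in one place: piperidin-1-yl in place of 4-methylcyclohexyl on a carbonyl carbon. Going by the values given here, no measured step bears directly on this exchange. The step of a 1.5-fold lower number from compound 1 to compound 2 (0.18 log units; within the scatter) alters only a substituent on the saturated ring and stays within the scatter, while compound 3 changes the attachment in more than one respect and gives no number at all. The change to compound 4 keeps the count of donors and acceptors unchanged and swaps one six-membered non-aromatic ring for another, so a modest shift is expected rather than a large one, with some risk of weakening. Compound 4 is therefore estimated at 3000 nM in this assay, with a range from 1000 nM to 10000 nM. That estimate corresponds to an expected step of a 2.0-fold higher number from compound 1 to compound 4 (0.30 log units; within the scatter).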

Compound 4, half-maximal effective concentration: 370 nM
Compound 4: the middle estimate sits 8.1-fold (0.91 log units) above what was measured; the measured number lies below the stated range.
By their numbers in this assay, from the lowest: compound 4; then compounds 2 and 1 (each within the scatter of the next). At a limit, above all of these: compound 3.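

For the compounds shown here, the step of a 4.1-fold lower number from compound 1 to compound 4 (0.61 log units; beyond the scatter) in this assay is the first in this account to lie beyond the scatter, so the group on this carbonyl carbon can move the number measurably, which the trifluoromethyl for methyl exchange, a 1.5-fold lower number from compound 1 to compound 2 (0.18 log units; within the scatter), did not show. Going by these compounds alone, the gain comes with a six-membered non-aromatic ring holding one hetero atom in place of a ring of carbon only, and so this position accepts piperidin-1-yl without any loss, though the single exchange removes the methyl and alters the ring at once, and the two changes cannot be told apart here. Nothing in hand accounts for the size of this step.

The compounds shown leave open whether plain cyclohexyl on the same carbonyl carbon would already give the lower number, or whether the ring nitrogen of piperidin-1-yl is what counts. They also leave open how 4-methylpiperidin-1-yl or morpholin-4-yl would fare at this position, and so whether the gain survives a substituent on the new ring or a second hetero atom within it.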